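A methyl added to compound 2

The source may report more compounds than this note shows. Statements on the series, on what has been measured and on what is new or still open speak of the compounds shown alone.

In a functional assay on SiHa cells (Homo sapiens) for inhibition, read by sulforhodamine B assay (a higher number here means a weaker inhibitor of growth, a lower number a stronger inhibitor of growth), compound 1 (`Cc1ccc2[nH]c(-c3ccc(-c4ccc(-c5cccc(Cl)c5)cc4)cc3)nc2c1`) gives 3600 nM and compound 2 (`Fc1ccc(-c2ccc(-c3ccc(-c4nc5ccccc5[nH]4)cc3)cc2)cc1`) gives 29700 nM, the higher of the two numbers, with the gap beyond the scatter. Compound 3 (`Cc1ccc2[nH]c(-c3ccc(-c4ccc(-c5ccc(F)cc5)cc4)cc3)nc2c1`) is compound 2 with methyl in place of hydrogen on an aromatic carbon. Compound 1 also carries a methyl but differs from compound 2 elsewhere as well, so compound 1 at 3600 nM is only a loose guide. The step expected in this assay is a 2.7-fold lower number from compound 2 to compound 3 (0.43 log units; beyond the scatter), toward a lower number and beyond the scatter. The estimated value for compound 3 is 11000 nM, with an expected range of 4000 nM to 28000 nM.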

Compound 3, concentration for 50% growth inhibition: 41000 nM
For compound 3 the middle estimate is 3.7-fold (0.57 log units) below the measured one, outside the stated range (above it).
By their numbers in this assay, from the lowest: compound 1; then compounds 2 and 3 (each within the scatter of the next).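

In this assay, methyl in place of hydrogen on an aromatic carbon gives a 1.4-fold higher number from compound 2 to compound 3 (0.14 log units; within the scatter), so with 4-fluorophenyl present, this methyl does not separate the two compounds. With the methyl present in both compounds, 4-fluorophenyl in place of 3-chlorophenyl gives an 11-fold higher number from compound 1 to compound 3 (1.06 log units; beyond the scatter), so here the large step goes with that aromatic group rather than with the methyl. No measured evidence accounts for either step. On these data alone, what the methyl does in a compound carrying 3-chlorophenyl remains open, as does the effect of an amine or a carboxylic acid at this position.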